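Fluorobenzothiazole in place of thiazolopyridine on the oxime ether series

A few compounds are considered here, and "the series" means these few. Any claim that something is new, unique, unknown or untested is made for them only; others in the source may bear on it.

Two compounds of the series carry numbers in a functional assay for inhibition of Polyunsaturated fatty acid 5-lipoxygenase (Homo sapiens); a lower number here means a stronger inhibitor, a higher number a weaker inhibitor. Compound 1 `C/C(CCCC(=O)O)=N\OC(c1ccc(OCc2ccc3ccccc3n2)cc1)C1CCCCC1` gives 59 nM. Compound 2 `O=C(O)/C=N/OC(c1ccc(OCc2nc3cccnc3s2)cc1)C1CCCCC1` gives 27 nM, the lower of the two numbers, and the gap to compound 1 lies beyond the usual scatter. Within the data shown here, no step between measured compounds is computed here, so only these two values are known.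

Compound 3 `O=C(O)/C=N/OC(c1ccc(OCc2nc3cc(F)ccc3s2)cc1)C1CCCCC1` differs from compound 2 in one place: a group of 10 heavy atoms (7 carbon, 1 nitrogen, 1 fluorine, 1 sulfur; one five-membered aromatic ring with 2 hetero atoms, one six-membered aromatic ring of carbon only) in place of a group of 9 heavy atoms (6 carbon, 2 nitrogen, 1 sulfur; one five-membered aromatic ring with 2 hetero atoms, one six-membered aromatic ring with 1 hetero atom), on a saturated chain carbon bound to an oxygen on an aromatic ring. The rest of the shared core, the oxime ether with its acid chain and the cyclohexyl carbinol, is untouched.

Among the measured compounds shown here, no measured pair shows the effect of such an exchange, so the step is expected to stay within the scatter, with no clear direction. The expected step from compound 2 to compound 3 is a 1.1-fold higher number from compound 2 to compound 3 (0.05 log units; within the scatter). Compound 3 is estimated at 30 nM in this assay, within a range of 12 nM to 75 nM.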

Compound 3, half-maximal inhibitory concentration: 87 nM
Compound 3: middle estimate off by 2.9-fold (0.46 log units), on the low side, and the stated range ends below it.
By their numbers in this assay, from the lowest: compound 2; then compounds 1 and 3 (each within the scatter of the next).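

Among these compounds, the first measured step shows that, in this assay, the group on a saturated chain carbon bound to an oxygen on an aromatic ring does affect the number: the exchange for 5-fluoro-1,3-benzothiazol-2-yl gives a weaker inhibitor (a 3.2-fold higher number from compound 2 to compound 3 (0.51 log units; beyond the scatter)). This position therefore does not accept the two groups as equivalent, even though both contain a five-membered aromatic ring with 2 hetero atoms. No measurement at hand accounts for the size or direction of this step.

The exchange alters the six-membered ring and adds fluorine in a single step, so the contribution of each remains unresolved. The unsubstituted 1,3-benzothiazol-2-yl group would separate the two, while a chlorine or methoxy group in the place of the fluorine would test how far the number depends on that substituent.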